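A few compounds are considered here, and "the series" means these few. Any claim that something is new, unique, unknown or untested is made for them only; others in the source may bear on it.

The account follows compound 1, `COC(=O)C[C@H](NC(=O)OC(C)(C)C)C(=O)N(Cc1ccccc1)C1(C(=O)NCc2ccccc2)CCN(Cc2ccccc2)CC1`, into compound 4, `COC(=O)C[C@H](NC(=O)OC(C)(C)C)C(=O)N(Cc1ccc(C)cc1)C1(C(=O)NCc2ccccc2)CCN(Cc2ccccc2)CC1`. In an ADME assay on MDCK cells (Canis lupus familiaris) for cytotoxicity, read by microscopy, with a stated time of 72 h (a higher number here means that more compound is tolerated, a lower number that less compound is tolerated), compound 1 gives > 100000 nM, and this is a limit of the assay rather than a number, so compound 1 stands only as a limit among the values shown. The study also holds compound 2, `COC(=O)C[C@H](NC(=O)OC(C)(C)C)C(=O)N(Cc1ccc(F)cc1)C1(C(=O)NCc2ccccc2)CCN(C)CC1`, which in this assay gives 17000 nM, and compound 3, `COC(=O)C[C@H](NC(=O)OC(C)(C)C)C(=O)N(Cc1ccc(F)cc1)C1(C(=O)NC2CCCCC2)CCN(Cc2ccccc2)CC1`, which in this assay gives 100000 nM. Among the measured compounds shown here, no two of the measured compounds differ in a single place, so no measured step is available; what marks compound 1 is the limit of > 100000 nM in this assay, at which 1 of the 3 values shown sits. Compound 4 differs from compound 1 by methyl in place of hydrogen on an aromatic carbon. For the measured compounds named here, with no measured step to lean on, no movement beyond the usual scatter is expected in this assay for this change. The step is expected to be a number no higher from compound 1 to compound 4 (the limit leaves the size open). Compound 4 is therefore estimated at 100000 nM in this assay, within a range from 30000 nM to 300000 nM, with a fair chance that the reading again stops at a limit.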

Compound 4, minimum cytotoxic concentration: > 100000 nM
Compound 4 gave a limit, no number; the forecaster's own chance of this, stated with the estimate: 60%; the middle value lies on the limit itself.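

In this assay, among the compounds shown here, compound 1 and compound 4 both read as limits of the assay rather than numbers, so no step between them can be read. The compounds shown leave open whether methyl in place of hydrogen on an aromatic carbon changes the tolerated concentration in this assay at all, and by how much.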